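Swapping an aminophenyl amide for a hydroxamic acid

The source may hold more compounds than are shown below. What is called first, only, known or untested is meant among the compounds shown, and "the series" means these compounds.

Compound 1 `Cn1cc(-c2ccccc2Oc2ccccc2)c2cc(C(=O)NCCCC(=O)NO)[nH]c2c1=O`: 144 nM
Compound 2 `Cn1cc(-c2ccccc2Oc2ccccc2)c2cc(C(=O)NCCCCCC(=O)NO)[nH]c2c1=O`: 3.4 nM
Compound 3 `Cn1cc(-c2ccccc2Oc2ccccc2)c2cc(C(=O)NCc3ccc(C(=O)Nc4ccccc4N)cc3)[nH]c2c1=O`: > 500 nM

All three measured compounds share one core and differ only in the group hanging from the amide nitrogen on the side chain. In an assay on isolated protein for inhibition of protein deacetylase HDAC6 (Homo sapiens), read by fluorescence (on this read-out higher numbers stand for weaker inhibition and lower numbers for stronger inhibition), compound 1 gives 144 nM and compound 2 gives 3.4 nM. Within the data shown here, the one measured step between them, a 42-fold lower number from compound 1 to compound 2 (1.63 log units; beyond the scatter), shows that a longer chain ending in hydroxycarbamoyl is rewarded strongly. Compound 3 carries a (2-aminophenyl)carbamoyl end instead, and for compound 3 the assay reports only a limit, not a number: > 500 nM. Compound 3 therefore sits at the limit of > 500 nM in this assay, at which 1 of the 3 values shown sits, the weak end of everything shown.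

Compound 4 `Cn1cc(-c2ccccc2Oc2ccccc2)c2cc(C(=O)NCc3ccc(C(=O)NO)cc3)[nH]c2c1=O` has not yet been measured. It differs from compound 3 in one place: hydroxy in place of 2-aminophenyl on an amide-type nitrogen. Among the measured compounds shown here, no measured step covers exactly this swap. What bears on it is that both compounds ending in hydroxycarbamoyl, compound 1 and compound 2, give real numbers in this assay, whereas compound 3, the only one without it, gives a limit. The step from compound 1 to compound 2 also shows that changes around the chain end can be large. The expected step is therefore a large move toward stronger inhibition, an at least 41-fold lower number from compound 3 to compound 4 (1.61 log units; beyond the scatter), when compound 3 is changed into compound 4. Compound 4 is estimated at 12 nM, with a likely range from 2 nM to 70 nM.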

Compound 4, half-maximal inhibitory concentration: 15.3 nM
Compound 4: the middle estimate sits 1.3-fold (0.11 log units) below what was measured, within the range that was stated.
By their numbers in this assay, from the lowest: compound 2; then compound 4; then compound 1. At a limit, above all of these: compound 3.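

In this assay, among these compounds, the swap of 2-aminophenyl for hydroxy on an amide-type nitrogen gives an at least 32-fold lower number from compound 3 to compound 4 (1.51 log units; beyond the scatter), the first comparison in which the end group alone changes while the rest of the side chain stays the same. The true step may be larger still, since compound 3 has only a limit and not a number: the limit of > 500 nM in this assay, at which 1 of the 4 values shown sits.

The result also brings in a ring-containing side chain, and 4-(hydroxycarbamoyl)phenyl lands between the two saturated chains, with a 9.4-fold lower number from compound 1 to compound 4 (0.97 log units; beyond the scatter) and a 4.5-fold higher number from compound 2 to compound 4 (0.65 log units; beyond the scatter), so a hydroxycarbamoyl end on a phenyl ring can compete with one on a saturated chain, though it does not match the better of the two.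

The compounds shown leave open how a carboxylic acid or a primary amide would fare in place of hydroxycarbamoyl on that phenyl ring. They also leave open whether a (2-aminophenyl)carbamoyl end on the longer saturated chain of compound 2 would give a real number, which would show whether the loss seen with that end holds on a different side chain.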